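This account rests on a few compounds, and the source may have more. Where it says the series, first, only, none or still open, it means among the compounds named here.

In a functional assay on A549 cells (Homo sapiens) for cytotoxicity, read by MTT assay, with a stated time of 24 h (a lower number here means a stronger inhibitor, a higher number a weaker inhibitor), compound 1 (`COc1ccc(/C=C(\C#N)C(=O)N/N=C(\C)c2c(O)c3ccc(O)cc3oc2=O)cc1`) gives 8150 nM and compound 2 (`COc1cc(/C=C(\C#N)C(=O)N/N=C(\C)c2c(O)c3ccc(O)cc3oc2=O)cc(OC)c1OC`) gives 15300 nM. These two values lie within the scatter of each other, so compound 1 does not stand apart. Compound 3 (`C/C(=N\NC(=O)/C(C#N)=C/c1ccccc1[N+](=O)[O-])c1c(O)c2ccc(O)cc2oc1=O`) has 2-nitrophenyl in place of 4-methoxyphenyl on a double-bonded chain carbon bound to a double-bonded chain carbon. Among the measured compounds shown here, no measured step isolates this change, so no shift beyond the scatter is expected in this assay, in either direction. The estimated step is a 1.2-fold higher number from compound 1 to compound 3 (0.09 log units; within the scatter). For compound 3 the expected value is 10000 nM, with an estimated range from 4000 nM to 25000 nM.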

Compound 3, half-maximal inhibitory concentration: 11400 nM
Compound 3: middle estimate off by 1.1-fold (0.06 log units), on the low side; low and high end bracket the measured number.
By their numbers in this assay, from the lowest: compounds 1, 3 and 2 (each within the scatter of the next).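

In this assay, among the compounds shown here, the exchange of 4-methoxyphenyl for 2-nitrophenyl on a double-bonded chain carbon bound to a double-bonded chain carbon gives a 1.4-fold higher number from compound 1 to compound 3 (0.15 log units; within the scatter) and so provides the first direct reading at this position, one that stays within the scatter. This single exchange alters both the ring substituent and its place on the ring, and the result does not separate the two. No available evidence accounts for the result. As far as these compounds go, whether a phenyl ring carrying an amine or a carboxylic acid at this position would shift the number remains open.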